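Nitro Substitution and Cytotoxic Potency in Two Related Cores

The source may hold more compounds than are shown below. What is called first, only, known or untested is meant among the compounds shown, and "the series" means these compounds.

Three compounds have been measured in a functional assay on Bel-7402 cells (Homo sapiens) for cytotoxicity, read by MTT assay, with a stated time of 48 h; on this read-out lower numbers stand for stronger inhibition and higher numbers for weaker inhibition:

Compound 1 `CCn1cc(-c2nc3ccccc3[nH]2)c(=O)c2cc(F)c(N3CCNC(C)C3)c(F)c21` gives 30200 nM.
Compound 2 `CCn1cc(-c2nc3ccccc3o2)c(=O)c2cc(F)c(N3CCNCC3)nc21` gives 16800 nM.
Compound 3 `CCn1cc(-c2nc3ccc([N+](=O)[O-])cc3[nH]2)c(=O)c2cc(F)c(N3CCNC(C)C3)c(F)c21` gives 1100 nM.

Compound 1 and compound 2 differ in their cores; that difference is not broken down here, and their two values lie within the usual scatter of each other. Compound 3 arises from compound 1 by one change, (nitro in place of hydrogen on an aromatic carbon), and this change made a large step: a 27-fold lower number from compound 1 to compound 3 (1.44 log units; beyond the scatter). Compound 3 also gives a clearly lower number than compound 2.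

Compound 4 `CCn1cc(-c2nc3ccc([N+](=O)[O-])cc3o2)c(=O)c2cc(F)c(N3CCNCC3)nc21` is not yet measured. It arises from compound 2 by the same change, (nitro in place of hydrogen on an aromatic carbon), at a place described in the same words as for compound 3. The step is therefore expected to resemble the earlier one, with some allowance for the different core, because the same change gave a 27-fold lower number from compound 1 to compound 3 (1.44 log units; beyond the scatter). The expected step is a 17-fold lower number from compound 2 to compound 4 (1.23 log units; beyond the scatter). For compound 4 the estimated value in this assay is 1000 nM, likely between 300 nM and 4000 nM.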

Compound 4, half-maximal inhibitory concentration: 3000 nM
Compound 4: middle estimate off by 3.0-fold (0.48 log units), on the low side, and the stated range covers the measured number.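

In this assay, putting a nitro group in place of hydrogen lowers the number on the second core as well, giving a 5.6-fold lower number from compound 2 to compound 4 (0.75 log units; beyond the scatter), so the direction of the change carries over from the core of compound 1 to the core of compound 2. The size of the step does not carry over, and the gap between the two steps is larger than repeated measurements would normally produce: the same change on two cores in this assay, a 27-fold lower number (1.44 log units; beyond the scatter) from compound 1 to compound 3 and a 5.6-fold lower number (0.75 log units; beyond the scatter) from compound 2 to compound 4, 4.9-fold (0.69 log units) apart, beyond the scatter of two such steps. This does not show what sets the size of the step, as compound 1 and compound 2 differ in more than one place and nothing here separates those differences, and two cores are too few to predict the step on a third.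

The compounds shown leave open whether another group on the same aromatic carbon, such as an amine or a nitrile, would lower the number as nitro does. They also leave open how a nitro group would behave on a different carbon of that six-membered ring.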